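The source may hold more compounds than are shown below. What is called first, only, known or untested is meant among the compounds shown, and "the series" means these compounds.

Of the compounds shown here, three that share one core have been measured in a physicochemical assay for lipophilicity, using the shake flask method, measured as octanol-water partition, at pH 7.4; on this read-out lower numbers stand for lower lipophilicity and higher numbers for higher lipophilicity. Compound 1 `CC(=O)N[C@@H]1CCC[C@H](C(=O)Nc2cc(-c3cnc(C)n3C)c(Cl)cn2)C1` gives 2.2, compound 2 `CC(=O)N[C@@H]1CCC[C@H](C(=O)Nc2cc(-c3nnn4ccccc34)c(Cl)cn2)C1` gives 2, and compound 3 `CC(=O)N[C@@H]1CCC[C@H](C(=O)Nc2cc(-c3cnc4n3CCC4)c(Cl)cn2)C1` gives 2.6, the highest of the three numbers.

The next compound, compound 4 `CC(=O)N[C@@H]1CCC[C@H](C(=O)Nc2cc(-c3cnn4c3CCCCC4)c(Cl)cn2)C1`, keeps the core and alters a single group: a group of 10 heavy atoms (8 carbon, 2 nitrogen; one five-membered aromatic ring with 2 hetero atoms, one seven-membered non-aromatic ring with 1 hetero atom) in place of a group of 8 heavy atoms (6 carbon, 2 nitrogen; one five-membered non-aromatic ring with 1 hetero atom, one five-membered aromatic ring with 2 hetero atoms), on an aromatic carbon. The group sits on an aromatic carbon, ortho to a chloro group, and the change swaps a five-membered non-aromatic ring for a seven-membered one. The entering group is larger, and its extra atoms are all carbon.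

The closest parallel is a number 0.40 log units higher from compound 1 to compound 3 (beyond the scatter), where the extra atoms of the larger group were also carbon, so a step upward of like or somewhat greater size is expected in this assay. Compound 2 is a warning against any simple rule of size: its group is the largest of the three measured, yet the numbers show a number 0.20 log units lower from compound 1 to compound 2 (within the scatter) and a number 0.60 log units higher from compound 2 to compound 3 (beyond the scatter). Within the data shown here, no measured compound carries a seven-membered ring, so the expectation stays loose.

The estimated step is a number 0.50 log units higher from compound 3 to compound 4 (beyond the scatter). The expected value for compound 4 is 3.1, with an estimated range from 2.7 to 3.5.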

Compound 4, distribution coefficient: 3.6
Estimate against measurement, compound 4: 0.50 log units below; the whole stated range lies below it.
By their numbers in this assay, from the lowest: compounds 2 and 1 (each within the scatter of the next); then compound 3; then compound 4.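

The step of a number 1.00 log units higher from compound 3 to compound 4 (beyond the scatter) in this assay shows that this position, on an aromatic carbon and ortho to a chloro group, can carry a far wider spread of numbers than the first three compounds suggested. Compound 4 stands well clear of the other two as well, with a number 1.40 log units higher from compound 1 to compound 4 (beyond the scatter) and a number 1.60 log units higher from compound 2 to compound 4 (beyond the scatter) as the remaining comparisons. The leaving and entering groups have the same counts of hydrogen-bond donors and acceptors, neither has a net charge, and the extra atoms are all carbon, but no measurement shown here explains the size of the rise.

As far as these compounds go, it remains open whether a six-membered non-aromatic ring in the same place would give a number between those of compound 3 and compound 4, which would show whether ring size alone tracks the read-out. From the compounds shown here alone, it is also open whether an ether oxygen or an amine nitrogen in the seven-membered ring would bring the number back down while keeping the size of the group.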